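Butyl Extension on the Phenyl Ring of Compound 2

The compounds below may be only part of what the source reports. "The series", "measured", "known", "first", "only" and "open" are said of these compounds alone.

Three measured compounds share one core. Compound 1 `CCCCCc1cc(-c2cn([C@H]3C[C@H](OC(C)=O)[C@@H](COC(C)=O)O3)c(=O)[nH]c2=O)on1` gives 88.9% in a functional assay on NCI-H23 cells (Homo sapiens) for cytotoxicity, read by sulforhodamine B assay, tested at 10 uM; on this read-out lower numbers stand for less inhibition and higher numbers for more inhibition at the one concentration tested (going by the name of the read-out). Compound 2 `CC(=O)OC[C@H]1O[C@@H](n2cc(-c3cc(-c4ccccc4)no3)c(=O)[nH]c2=O)C[C@@H]1OC(C)=O` gives 91.4% in this assay, and compound 3 `CC(C)(C)c1ccc(Cn2cc(-c3cn([C@H]4C[C@H](O)[C@@H](CO)O4)c(=O)[nH]c3=O)nn2)cc1` gives 95%. Compound 2 stands second of the three numbers, yet within the scatter of both other compounds. Among the measured compounds shown here, the only single-point step measured so far, a number 2.5 percentage points higher from compound 1 to compound 2 (within the scatter), moved the read-out no further than the scatter. Compound 4 `CCCCc1ccc(-c2cc(-c3cn([C@H]4C[C@H](OC(C)=O)[C@@H](COC(C)=O)O4)c(=O)[nH]c3=O)on2)cc1` differs from compound 2 by butyl in place of hydrogen on an aromatic carbon. For the measured compounds named here, no measured step adds a chain at this place, so the expectation rests on the flat pentyl-to-phenyl exchange and the narrow spread of all three values. Compound 4 is therefore expected at 91%, between 80% and 97%. The expected step is a number 0.4 percentage points lower from compound 2 to compound 4 (within the scatter), nothing beyond the scatter.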

Compound 4, a percentage reported as inhibition, at one concentration (the size of the read-out at that concentration, not a potency): 97.4%
Beside the measured number, compound 4's estimate is 6.4 percentage points below it, outside the stated range (above it).
By their numbers in this assay, from the lowest: compounds 1, 2, 3 and 4 (each within the scatter of the next).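

Adding butyl to the phenyl ring gives a number 6 percentage points higher from compound 2 to compound 4 (within the scatter) in this assay, so this aromatic carbon, para to a large group, carries the chain without the read-out leaving the scatter. Exchanging pentyl for 4-butylphenyl gives a number 8.5 percentage points higher from compound 1 to compound 4 (within the scatter), so that exchange does not separate the two compounds either. Nothing available explains these numbers.

Whether the butyl chain has any effect at all stays unsettled at a single concentration. Going by these compounds, whether an amine, a carboxylic acid or a longer chain at this place would hold the number also remains open.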